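Benzyl sulfide variation: chloro to methyl on compound 2

This account rests on a few compounds, and the source may have more. Where it says the series, first, only, none or still open, it means among the compounds named here.

Working notes on the series. In a functional assay on HGC-27 cells (Homo sapiens) for inhibition, read by MTT assay, with a stated time of 72 h (a higher number here means a weaker inhibitor, a lower number a stronger inhibitor), compound 2 `Cc1cc(N2CC[C@@H](C)[C@@H](N(C)c3ncnc4[nH]ccc34)C2)n2nc(SCc3ccc(Cl)cc3)nc2n1` gives 18400 nM, and the only other plain number shown belongs to compound 1 `Cc1cc(N2CC[C@@H](C)[C@@H](N(C)c3ncnc4[nH]ccc34)C2)n2nc(SCC3CCCCC3)nc2n1`, which gives 11500 nM, within the scatter of compound 2. For compound 3 `Cc1nc2nc(SCc3ccc(Cl)cc3)nn2c(N2CC[C@@H](C)[C@@H](N(C)c3ncnc4[nH]ccc34)C2)c1C` the assay returns only a limit, > 100000 nM. Compound 4 `Cc1ccc(CSc2nc3nc(C)cc(N4CC[C@@H](C)[C@@H](N(C)c5ncnc6[nH]ccc56)C4)n3n2)cc1` differs from compound 2 by methyl in place of chloro on an aromatic carbon. For the measured compounds named here, two measured steps bear on this: the change at the same end of the chain, a 1.6-fold higher number from compound 1 to compound 2 (0.20 log units; within the scatter), and the methyl added elsewhere, an at least 5.4-fold higher number from compound 2 to compound 3 (0.73 log units; beyond the scatter). Only the first touches the same group, so no step beyond the scatter is expected: a 1.0-fold lower number from compound 2 to compound 4 (0.01 log units; within the scatter). Compound 4 is therefore estimated at 18000 nM, within a range from 7000 nM to 45000 nM.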

Compound 4, half-maximal inhibitory concentration: 15200 nM
Beside the measured number, compound 4's estimate is 1.2-fold (0.07 log units) above it; the measured number falls inside the stated range.
By their numbers in this assay, from the lowest: compounds 1, 4 and 2 (each within the scatter of the next). At a limit, above all of these: compound 3.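

In this assay, on an aromatic carbon para to a large group, methyl in place of chloro gives a 1.2-fold lower number from compound 2 to compound 4 (0.08 log units; within the scatter). The comparison with the saturated ring gives a 1.3-fold higher number from compound 1 to compound 4 (0.12 log units; within the scatter), so cyclohexyl, 4-chlorophenyl and 4-methylphenyl show no separation at this end of the chain. Nothing shown gives a cause for this.

As far as these compounds go, whether an amine or a carboxylic acid at this aromatic carbon, or a longer chain on the sulfur, would give a step beyond the scatter stays open. Also open, from the compounds shown here alone, is how the methyl that separates compound 3 from compound 2 behaves with 4-methylbenzyl in place of 4-chlorobenzyl.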